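From 2-methylphenyl to 2-methoxybenzyl in compound 4

The compounds below may be only part of what the source reports. "The series", "measured", "known", "first", "only" and "open" are said of these compounds alone.

Compound 1 `Cc1ccccc1Nc1nc(Nc2ccc(N3CCN(C)CC3)cn2)ncc1Cl`: 8080 nM
Compound 2 `CCN1CCN(c2ccc(Nc3ncc(Cl)c(Nc4ccccc4C)n3)nc2)CC1`: > 100000 nM
Compound 3 `Cc1ccccc1Nc1nc(Nc2ccc(N3CCNCC3)cn2)ncc1Cl`: 7870 nM

Among the measured compounds shown here, in a functional assay on Jurkat cells (Homo sapiens) for inhibition, read by CCK-8 assay, with a stated time of 48 h (a lower number here means a stronger inhibitor of growth, a higher number a weaker inhibitor of growth), compound 1 gives 8080 nM, and the only other exact number lies within the scatter of it: a 1.0-fold lower number from compound 1 to compound 3 (0.01 log units; within the scatter). For compound 2 the reading > 100000 nM is a limit of the assay, not a number. Compound 4 `COc1ccccc1CNc1nc(Nc2ccc(N3CCN(C)CC3)cn2)ncc1Cl` carries 2-methoxybenzyl in place of 2-methylphenyl on a nitrogen on an aromatic ring. For the measured compounds named here, no measured step touches this place, since all of them alter the group on an amine nitrogen in a ring. One of those steps is large, an at least 12-fold higher number from compound 1 to compound 2 (1.09 log units; beyond the scatter), so the range must stay wide. The best expectation is no step beyond the scatter, leaning toward a higher number. The estimated step is a 1.5-fold higher number from compound 1 to compound 4 (0.17 log units; within the scatter). For compound 4 the estimated value is 12000 nM, with an expected range from 3000 nM to 60000 nM.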

Compound 4, concentration for 50% growth inhibition: 10800 nM
Estimate against measurement, compound 4: 1.1-fold (0.05 log units) above; the range from low to high includes it.
By their numbers in this assay, from the lowest: compounds 3, 1 and 4 (each within the scatter of the next). At a limit, above all of these: compound 2.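

In this assay the change from (2-methylphenyl)amino to (2-methoxybenzyl)amino gives a 1.3-fold higher number from compound 1 to compound 4 (0.13 log units; within the scatter) and so no real shift. Among the compounds shown here, the earlier compounds varied only the group on an amine nitrogen in a ring, so this is the first reading at this place. It takes a group with more heavy atoms and a hydrogen-bond acceptor without a change beyond the scatter.

Going by these compounds, whether a longer chain or a carboxylic acid here would move the number stays open. No measurement shown gives a reason for this result.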